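The source may report more compounds than this note shows. Statements on the series, on what has been measured and on what is new or still open speak of the compounds shown alone.

In an ADME assay on CEMx174 cells (Homo sapiens) for cytotoxicity (on this read-out lower numbers stand for higher toxicity in this test and higher numbers for lower toxicity in this test), three compounds sharing one core have been tested so far, and none gives a plain number. Compound 1 `CCCC1=C(C(=O)OCC2CCCCC2)C(c2cccc(O)c2)NC(=O)N1`, with a propyl group, gives the limit > 10000 nM. Compound 2 `O=C1NC(C2CC2)=C(C(=O)OCC2CCCCC2)C(c2cccc(O)c2)N1`, with a cyclopropyl group, gives the limit > 10000 nM. Compound 3 `O=C1NC(CCl)=C(C(=O)OCC2CCCCC2)C(c2cccc(O)c2)N1`, with a chloromethyl group, gives the limit > 3000 nM, so its standing is known only as a limit, as with the other two. Compound 4 `O=C1NC(c2ccccc2)=C(C(=O)OCC2CCCCC2)C(c2cccc(O)c2)N1` carries phenyl in place of chloromethyl on a double-bonded ring carbon. The closest evidence is a step that the two limits leave unreadable from compound 2 to compound 3, where chloromethyl also changes places with another group. The others, a step that the two limits leave unreadable from compound 1 to compound 2 and a step that the two limits leave unreadable from compound 1 to compound 3, offer no readable size either. That leaves the overall picture: the limit of > 10000 nM in this assay, at which 2 of the 3 values shown sit, and (the limit of > 3000 nM in this assay, at which 1 of the 3 values shown sits). The expected change is a step that the limit leaves unreadable from compound 3 to compound 4, with no step beyond the usual scatter expected in either direction. Compound 4 may well return only a limit too. Compound 4 is estimated at 10000 nM, with an expected range from 3000 nM to 30000 nM.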

Compound 4, half-maximal cytotoxic concentration: > 10000 nM
Compound 4 gave a limit, no number; the forecaster's own chance of this, stated with the estimate: 85%; the middle value lies on the limit itself.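

In this assay compound 4 gives only a limit, > 10000 nM. Going by these compounds alone, compound 1, compound 2 and compound 3 also give only limits, so no step to compound 4 can be read. The compounds shown leave open at what concentration any of them becomes toxic to these cells.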